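The source may report more compounds than this note shows. Statements on the series, on what has been measured and on what is new or still open speak of the compounds shown alone.

Series notes. The shared core of compound 1 `O=C1C(c2ccccc2)CC(c2ccccc2)C(=O)N1c1ccccc1` carries two phenyl groups and a phenyl on the imide nitrogen; in a functional assay on the whole organism (strain Swiss albino) for inhibition, with Mus musculus as the target, in the maximal electroshock model, with a stated time of 2 h, at a dose of 25 mg/kg by the intraperitoneal route (on this read-out higher numbers stand for more inhibition at the one dose given (going by the name of the read-out) and lower numbers for less inhibition), compound 1 gives 38.3%. Compound 2 `O=C1C(c2ccccc2Cl)CC(c2ccccc2Cl)C(=O)N1c1ccccc1` carries a chlorine on each of the two aryl rings at the core; in this assay compound 2 gives 40.6%. The two values lie within the usual scatter of each other, so the numbers for compound 1 and compound 2 show no separation.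

Compound 3 `Cc1ccccc1N1C(=O)C(c2ccccc2Cl)CC(c2ccccc2Cl)C1=O` is the next member. It differs from compound 2 in one place: methyl in place of hydrogen on an aromatic carbon. Going by the values given here, no measured pair in this set shares that change, so there is no recorded step to lean on. Among the compounds with values here, the two numbers so far sit close together, and nothing suggests a move beyond the scatter. For compound 3 the step of a number 1.4 percentage points higher from compound 2 to compound 3 (within the scatter) is expected to be small. In this assay compound 3 is estimated at 42%, with a range from 25% to 60%.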

Compound 3, a percentage reported as inhibition, in the whole organism at one dose (the size of the read-out at that dose, not a potency): 60.6%
The estimate for compound 3 lay 18.6 percentage points below the measured number; measured number outside the range, above it.
By their numbers in this assay, from the lowest: compounds 1 and 2 (each within the scatter of the next); then compound 3.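

In this assay, going by these compounds alone, the change from phenyl to 2-methylphenyl gives a number 20 percentage points higher from compound 2 to compound 3 (beyond the scatter), the first single-place change that can be read. A methyl on an aromatic carbon ortho to a large group, only 1 heavy atom with no ring and no charge, is therefore enough to move this read-out beyond the scatter. Nothing measured here accounts for the rise.

Whether the rise is specific to methyl remains open, since the compounds shown leave unanswered how an ethyl, a methoxy group or an amine at that place would read. On these data alone, it is also open whether the same methyl would give a similar step on compound 1, which has no chlorine on its two aryl rings at the core.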